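The compounds below may be only part of what the source reports. "The series", "measured", "known", "first", "only" and "open" are said of these compounds alone.

Measured so far in a physicochemical assay for lipophilicity, measured as octanol-water partition, at pH 7.4 (on this read-out higher numbers stand for higher lipophilicity and lower numbers for lower lipophilicity), are three compounds:
compound 1 `Cc1ccc2[nH]c(C(=O)N[C@H]3CCN(C(=O)c4cccnc4)C[C@@H]3C(=O)NCCN(C)C)cc2c1` gives 0.7
compound 2 `Cc1ccc2[nH]c(C(=O)N[C@@H]3CN(S(=O)(=O)c4ccccc4)C[C@H]3C(=O)NCCN(C)C)cc2c1` gives 2.1
compound 3 `O=C(N[C@H]1CN(S(=O)(=O)c2ccccc2)C[C@@H]1C(=O)N[C@H]1CCCNC1)c1cc(C2CC2)n[nH]1` gives 0.2

Compound 3 (at 0.2) stands lowest of the three. Compound 1 (at 0.7) lies nearest above it and compound 2 (at 2.1) furthest, and both gaps are beyond the usual scatter of repeated measurements. No two of these compounds differ in just one place, so the numbers give no direct measure of what a single swap does.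

The next compound to be measured is compound 4 `O=C(N[C@H]1CN(S(=O)(=O)c2ccccc2)C[C@@H]1C(=O)N[C@H]1CCCNC1)c1cc(-c2ccc(Cl)cc2)on1`. Relative to compound 3, 5-(4-chlorophenyl)-1,2-oxazol-3-yl takes the place of 3-cyclopropyl-1H-pyrazol-5-yl on a carbonyl carbon (5-(4-chlorophenyl)-1,2-oxazol-3-yl in place of 3-cyclopropyl-1H-pyrazol-5-yl on a carbonyl carbon). The group that enters holds a chlorine and a six-membered aromatic ring of carbon only, and the group that leaves holds neither. Going by the values given here, a clear rise in this assay is expected from this swap, although no measured pair confirms its size. Compound 2 (at 2.1) stands highest of the three and serves as a rough guide. An upward move is expected, with an estimated a number 1.70 log units higher from compound 3 to compound 4 (beyond the scatter) that lies beyond the scatter. Compound 4 is estimated to give 1.9 (expected range 1.3 to 2.6).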

Compound 4, distribution coefficient: 2.1
Compound 4: middle estimate off by 0.20 log units, on the low side; the measured number falls inside the stated range.
By their numbers in this assay, from the lowest: compound 3; then compound 1; then compounds 2 and 4 (each within the scatter of the next).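

Going by these compounds alone, compound 3 and compound 4 form the first pair here that differs in one place, so this assay now gives a direct reading for a single swap on a carbonyl carbon whose other neighbour is an amide-type nitrogen, namely a number 1.90 log units higher from compound 3 to compound 4 (beyond the scatter). This one swap bundles several changes: 5-(4-chlorophenyl)-1,2-oxazol-3-yl brings a chlorine and a six-membered aromatic ring of carbon only, and it holds no hydrogen-bond donor, whereas 3-cyclopropyl-1H-pyrazol-5-yl holds one donor and a three-membered ring. The step therefore describes the exchange as a whole, and no measurement is available to explain it or to assign it to any one of these changes.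

The compounds shown leave open how much of the step belongs to the chlorine, and a plain 5-phenyl-1,2-oxazol-3-yl group, which is the same group without that atom, would be the direct comparison. They also leave open whether the same swap moves the number by a similar amount on a different part of the series, such as the core of compound 1.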